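The compounds below may be only part of what the source reports. "The series", "measured", "known", "first", "only" and "open" are said of these compounds alone.

Compound 1 `C=C1C(=O)[C@]23C[C@@]1(Cl)CC[C@H]2[C@@]12C=CC(=O)[C@](C)(C(=O)O1)[C@H]2[C@@H]3C(=O)OC`: 39800 nM
Compound 2 `C=C1C(=O)[C@]23C[C@@]1(Cl)CC[C@H]2[C@@]12C=CC(=O)[C@](C)(C(=O)O1)[C@H]2[C@@H]3C(=O)OCc1ccccc1`: 17900 nM

Going by the values given here, in a functional assay on HepG2 cells (Homo sapiens) for cytotoxicity, read by MTT assay (on this read-out lower numbers stand for stronger inhibition and higher numbers for weaker inhibition), compound 1 gives 39800 nM as the higher of the two numbers measured so far, which makes it the less active of the pair. Among the compounds with values here, the only measured step (a 2.2-fold lower number from compound 1 to compound 2 (0.35 log units; beyond the scatter)) puts phenyl in place of hydrogen on a saturated chain carbon and leaves the chloro group untouched.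

Compound 3 (`C=C1C(=O)[C@]23C[C@@]1(OC)CC[C@H]2[C@@]12C=CC(=O)[C@](C)(C(=O)O1)[C@H]2[C@@H]3C(=O)OC`) has not yet been measured. It keeps the core of compound 1 and carries a single change (methoxy in place of chloro on a saturated ring carbon), methoxy in place of chloro on a saturated ring carbon. Within the data shown here, no measured pair tests this swap, so the data cannot say which way the number should move. Among the measured compounds shown here, with only that modest step (a 2.2-fold lower number from compound 1 to compound 2 (0.35 log units; beyond the scatter)) as a guide, a large shift seems unlikely, and no step beyond the scatter is expected. The estimated change is a 1.1-fold higher number from compound 1 to compound 3 (0.05 log units; within the scatter) in this comparison. For compound 3 the expected value is 45000 nM in this assay, with an estimated range from 18000 nM to 100000 nM for repeated measurements.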

Compound 3, half-maximal inhibitory concentration: 43500 nM
For compound 3 the middle estimate is 1.0-fold (0.01 log units) above the measured one; measured number inside the range.
By their numbers in this assay, from the lowest: compound 2; then compounds 1 and 3 (each within the scatter of the next).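

Going by these compounds alone, the earlier step (a 2.2-fold lower number from compound 1 to compound 2 (0.35 log units; beyond the scatter)) changed a saturated chain carbon, so compound 3 gives the first reading at this saturated ring carbon of the five-membered ring. In this assay, replacing chloro with methoxy gives a 1.1-fold higher number from compound 1 to compound 3 (0.04 log units; within the scatter), which means that exchanging a single chlorine for a group of two heavy atoms, including an oxygen counted as a hydrogen-bond acceptor, produces no difference that can be told from the scatter at this position. No available evidence bears on this result, so the data offer no explanation for it.

On these data alone, this single swap shows only how chloro and methoxy compare at this position, so it cannot show whether the position would tolerate other kinds of group, and the outcome for an amine, a hydroxyl group or a longer chain such as ethoxy remains open. As far as these compounds go, it also remains open whether the benzyl ester of compound 2 would have the same effect on the methoxy compound as it does on the chloro compound.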